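Swapping the Urea Linker of Compound 2 for an Amide

A few compounds are considered here, and "the series" means these few. Any claim that something is new, unique, unknown or untested is made for them only; others in the source may bear on it.

Compound 1 `COc1cc(-c2nn(-c3cccc(NC(=O)c4cccc(C(F)(F)F)c4)c3)cc2-c2ccncc2)ccc1Cl`: in a functional assay on A549 cells (Homo sapiens) for inhibition, read by sulforhodamine B assay, with a stated time of 48 h (on this read-out lower numbers stand for stronger inhibition of growth and higher numbers for weaker inhibition of growth), compound 1 gives > 50000 nM, which is a limit of the assay and not a number.
Compound 2 `COc1cc(-c2nn(-c3cccc(NC(=O)Nc4ccc(Cl)c(Cl)c4)c3)cc2-c2ccncc2)ccc1Cl`: in this assay compound 2 gives > 50000 nM, again a limit.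
Compound 3 `O=C(Nc1cccc(-n2cc(-c3ccncc3)c(-c3ccc(Cl)c(O)c3)n2)c1)Nc1ccc(Cl)c(Cl)c1`: in this assay compound 3 gives > 32500 nM, also a limit.

Compound 2 therefore stands at a limit, as do both other measured compounds, so none of the three can be ranked against the others. Compound 4 `COc1cc(-c2nn(-c3cccc(NC(=O)c4ccc(Cl)c(C(F)(F)F)c4)c3)cc2-c2ccncc2)ccc1Cl` differs from compound 2 in one place: 4-chloro-3-(trifluoromethyl)phenyl in place of (3,4-dichlorophenyl)amino on a carbonyl carbon. The step at this same carbonyl carbon, a step that the two limits leave unreadable from compound 1 to compound 2, is the one that bears on this change, and the other step, a step that the two limits leave unreadable from compound 2 to compound 3, lies elsewhere in the molecule; neither has a readable size, since the values sit at the limit of > 50000 nM in this assay, at which 2 of the 3 values shown sit, and at the limit of > 32500 nM in this assay, at which 1 of the 3 values shown sits. No direction can be taken from them. Because compound 1 gives > 50000 nM with an amide of closely related shape, compound 4 is expected to remain at or near the limit as well. The expected step that the limit leaves unreadable from compound 2 to compound 4 is thus no step beyond the scatter. Compound 4 is estimated at 60000 nM, with a range from 20000 nM to 200000 nM.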

Compound 4, concentration for total growth inhibition: > 32500 nM
Compound 4: a limit, no number (the forecaster's own chance of this, stated with the estimate: 85%); the middle value lies beyond the limit too.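

In this assay compound 4 gives > 32500 nM, which is a limit and not a number, so its steps from compound 1 and from compound 2 cannot be read. The compounds shown leave open whether changing the group on the carbonyl carbon alters growth inhibition at all.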